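A few compounds are considered here, and "the series" means these few. Any claim that something is new, unique, unknown or untested is made for them only; others in the source may bear on it.

Measured in a functional assay on HCT-8 cells (Homo sapiens) for antiproliferative activity, read by MTT assay, with a stated time of 48 h; a lower number here means a stronger inhibitor, a higher number a weaker inhibitor:
compound 1 `COc1ccc2c(/C=C/C(=O)c3cc(N)c(OC)c(OC)c3)cn(C)c2c1`: 455 nM
compound 2 `COc1cc(C(=O)/C=C/c2cn(C)c3ccccc23)cc(SC)c1OC`: 210 nM

Compound 2 gives 210 nM, the lower of the two numbers, and the gap to compound 1 lies beyond the scatter. Compound 3 `COc1cc(C(=O)/C=C/c2cn(C)c3ccccc23)cc(N)c1OC` keeps the core of compound 2 and has amino in place of methylsulfanyl on an aromatic carbon, ortho to a methoxy group (amino in place of methylsulfanyl on an aromatic carbon). Within the data shown here, no measured step isolates this exchange. Compound 1 also carries amino and gives 455 nM, but its core differs from the core of compound 2, so it offers only loose guidance. In this assay, no step beyond the scatter is expected, and the estimate is a 1.2-fold higher number from compound 2 to compound 3 (0.08 log units; within the scatter). For compound 3 the expected value is 250 nM, with an estimated range of 60 nM to 1000 nM.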

Compound 3, half-maximal inhibitory concentration: 605 nM
The estimate for compound 3 lay 2.4-fold (0.38 log units) below the measured number; the range from low to high includes it.
By their numbers in this assay, from the lowest: compound 2; then compounds 1 and 3 (each within the scatter of the next).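

In this assay, this position, ortho to a methoxy group, responds to the exchange: amino in place of methylsulfanyl gives a 2.9-fold higher number from compound 2 to compound 3 (0.46 log units; beyond the scatter), so on this core methylsulfanyl gives the lower number of the two groups. With amino held constant, hydrogen in place of methoxy on an aromatic carbon gives a 1.3-fold higher number from compound 1 to compound 3 (0.12 log units; within the scatter), so this second change does not separate the two amino compounds. Nothing in hand accounts for the gap between amino and methylsulfanyl.

Open, on these data alone, is how a hydroxyl or ethylsulfanyl group would compare at this position on the core shared by compound 2 and compound 3. Also open, as far as these compounds go, is whether the exchange of amino and methylsulfanyl would give a similar step on the core of compound 1.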